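The source may hold more compounds than are shown below. What is called first, only, known or untested is meant among the compounds shown, and "the series" means these compounds.

Working notes on the series, read in a functional assay on ASPC1 cells (Homo sapiens) for cytotoxicity; on this read-out higher numbers stand for weaker inhibition and lower numbers for stronger inhibition. Among the compounds with values here, compound 1 (`CS(=O)(=O)c1ccc2nc(NC(=O)CCCCCCC(=O)NO)sc2c1`) gives 13.5 ug/mL, the only true number so far. Compound 2 (`CS(=O)(=O)c1ccc2nc(NC(=O)CCCCC(=O)NO)sc2c1`) gives > 30 ug/mL, which is a limit of the assay and not a number.

Within the data shown here, the single measured step is an at least 2.2-fold higher number from compound 1 to compound 2 (0.34 log units; beyond the scatter). It comes from hydroxycarbamoyl in place of 2-(hydroxycarbamoyl)ethyl on a saturated chain carbon, so it concerns the chain and not the aromatic substituent.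

Compound 3 (`O=C(CCCCCCC(=O)Nc1nc2ccc([N+](=O)[O-])cc2s1)NO`) is still to be measured in this assay. Its difference from compound 1 is nitro in place of methylsulfonyl on an aromatic carbon, in words nitro in place of methylsulfonyl on an aromatic carbon, with the chain of compound 1 kept. Among the measured compounds shown here, no measured step covers a change at this aromatic carbon, so the step in the chain gives no guide to its size or direction. The starting point therefore remains compound 1 at 13.5 ug/mL, with a wide margin on either side.

The estimated change is a 1.1-fold lower number from compound 1 to compound 3 (0.05 log units; within the scatter), and no shift beyond the scatter is expected. For compound 3 the expected value is 12 ug/mL, within an estimated range from 5 ug/mL to 28 ug/mL.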

Compound 3, half-maximal inhibitory concentration: 1.65 ug/mL
Compound 3: the middle estimate sits 7.3-fold (0.86 log units) above what was measured; the whole stated range lies above it.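

In this assay, nitro in place of methylsulfonyl on this aromatic carbon gives an 8.2-fold lower number from compound 1 to compound 3 (0.91 log units; beyond the scatter), with the chain kept unchanged. This shows that the aromatic substituent, and not only the chain, moves the read-out in this series, and that a swap between two groups with the same counts of hydrogen-bond donors and acceptors can still give a step beyond the scatter, so those counts alone do not account for the difference between these two groups. The values shown give no measured property of either group, and nothing here bears on the cause of this step.

Other groups at this aromatic carbon remain open, for example an amine, a carboxylic acid or a nitrile, so one step cannot show whether the read-out follows any trend across substituents at this position. It is also open whether the step seen with nitro carries over to a shorter or a longer chain, since the swap is shown on a single chain only.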